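Swapping the Aryl Substituent on a Shared Amide Arm

The compounds below may be only part of what the source reports. "The series", "measured", "known", "first", "only" and "open" are said of these compounds alone.

Of the compounds shown here, three with the same core have been measured so far. Compound 1 `CN(C)C(=O)c1cc2cnc(Nc3ccc(NC(=O)C4(C(=O)Nc5ccccc5)CC4)cc3)nc2n1C1CCCC1` carries an unsubstituted phenyl on the outer amide, and in a functional assay on A549 cells (Homo sapiens) for inhibition, read by CCK-8 assay, with a stated time of 72 h, tested at 10 uM (a lower number here means less inhibition of growth, a higher number more inhibition of growth at the concentration tested), compound 1 gives 88.8%. Compound 2 `CN(C)C(=O)c1cc2cnc(Nc3ccc(NC(=O)C4(C(=O)Nc5cccc(C(F)(F)F)c5)CC4)cc3)nc2n1C1CCCC1` carries a trifluoromethyl on that phenyl, and in this assay compound 2 gives 89.2%. Compound 3 `CN(C)C(=O)c1cc2cnc(Nc3ccc(NC(=O)C4(C(=O)Nc5cccc(Br)c5)CC4)cc3)nc2n1C1CCCC1` carries a bromo there, and in this assay compound 3 gives 92.2%. On the numbers shown, compound 2 sits between the other two, nearest to compound 1 and furthest from compound 3, yet all three lie within the scatter of one another. The steps of a number 0.4 percentage points higher from compound 1 to compound 2 (within the scatter) and a number 3 percentage points higher from compound 2 to compound 3 (within the scatter) show that exchanging the group on this phenyl has not moved the read-out beyond the scatter.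

Compound 4 `CN(C)C(=O)c1cc2cnc(Nc3ccc(NC(=O)C4(C(=O)Nc5ccc(O)cc5)CC4)cc3)nc2n1C1CCCC1` is not yet measured. It differs from compound 2 in one place: 4-hydroxyphenyl in place of 3-(trifluoromethyl)phenyl on an amide-type nitrogen. The two earlier steps on this same ring bear on it directly, and both were small. A hydroxy group has not been tried before, so a wider range is reasonable, but the expected step is a number 2.2 percentage points lower from compound 2 to compound 4 (within the scatter), which stays within the scatter. Compound 4 is therefore expected to give 87% in this assay, with a range from 74% to 95%.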

Compound 4, percent growth inhibition at one concentration: 94.4%
Estimate against measurement, compound 4: 7.4 percentage points below, within the range that was stated.
By their numbers in this assay, from the lowest: compounds 1, 2, 3 and 4 (each within the scatter of the next).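

Until now, this ring on the outer amide had carried only hydrogen, trifluoromethyl or bromo, none of which adds a hydrogen-bond donor. The 4-hydroxyphenyl group brings in both a hydrogen-bond donor and a hydrogen-bond acceptor, yet the read-out stays within the scatter of all three earlier compounds: a number 5.2 percentage points higher from compound 2 to compound 4 (within the scatter), a number 2.2 percentage points higher from compound 3 to compound 4 (within the scatter) and a number 5.6 percentage points higher from compound 1 to compound 4 (within the scatter). In this assay, the four aryl groups on this amide-type nitrogen therefore cannot be told apart, and nothing measured here gives a reason for that sameness.

An amine or a carboxylic acid on this ring, or a longer chain in place of the phenyl altogether, could show whether this position accepts still larger changes without moving the read-out beyond the scatter. Each of the four compounds also has a reading at only one concentration, which leaves open whether they would separate at a lower one.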